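Shrinking the oxime ether on the aryl-imidazoline core

The source may hold more compounds than are shown below. What is called first, only, known or untested is meant among the compounds shown, and "the series" means these compounds.

Measured compounds in a functional assay for activation of Alpha-1D adrenergic receptor (Homo sapiens); a lower number here means that less compound is needed, a higher number that more compound is needed for the effect:
Compound 1 `Cc1nc(-c2ccccc2NCC2=NCCN2)cs1` reports only a limit, < 5020 nM.
Compound 2 `c1csc(-c2ccccc2NCC2=NCCN2)c1` gives 18.2 nM.
Compound 3 `CCO/N=C(\C)c1ccccc1NCC1=NCCN1` reports only a limit, < 5020 nM.

Compound 3 thus stands on a limit of this assay, not on a number, and it shares that limit with compound 1 (the limit of < 5020 nM in this assay, at which 2 of the 3 values shown sit). Compound 4 `CO/N=C/c1ccccc1NCC1=NCCN1` differs from compound 3 by a group of 4 heavy atoms (2 carbon, 1 nitrogen, 1 oxygen; no ring) in place of a group of 6 heavy atoms (4 carbon, 1 nitrogen, 1 oxygen; no ring), on an aromatic carbon. Among the compounds with values here, the steps that reach compound 3, a step that the two limits leave unreadable from compound 1 to compound 3 and a step that the limit leaves unreadable from compound 2 to compound 3, are both unreadable in size, so no measured step shows what this kind of change does in this assay. Compound 4 is therefore expected to sit near compound 3, and the expected step that the limit leaves unreadable from compound 3 to compound 4 is set at no change beyond the scatter. Compound 4 is estimated at 1500 nM, in the range 60 nM to 5020 nM.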

Compound 4, half-maximal effective concentration: < 5020 nM
Compound 4 ended at the assay's limit; the forecaster's own chance of this, stated with the estimate: 50%; the middle value is on the limit's open side.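

In this assay, within the data shown here, compound 4 gives < 5020 nM as a limit, so no step joining it to compound 1, compound 2 or compound 3 can be read: the limit of < 5020 nM in this assay, at which 3 of the 4 values shown sit. The compounds shown leave open how far the different groups in compound 3 and compound 4 alter the effect.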